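The source may hold more compounds than are shown below. What is called first, only, known or untested is meant among the compounds shown, and "the series" means these compounds.

Compound 1 `CCCN(CC[C@H]1CC[C@H](NC(=O)/C=C/c2cccc(F)c2)CC1)[C@H]1CCc2nc(N)sc2C1` is tested in an assay on brain for displacement of a labelled ligand from D(3) dopamine receptor (Rattus norvegicus); on this read-out higher numbers stand for weaker inhibition and lower numbers for stronger inhibition; in this assay compound 1 gives 9.9 nM, the highest number among the three measured compounds. Compound 2 `CCCN(CC[C@H]1CC[C@H](NC(=O)/C=C/c2ccc(OC)cc2)CC1)[C@H]1CCc2nc(N)sc2C1` gives 6.7 nM, and compound 3 `CCCN(CC[C@H]1CC[C@H](NC(=O)c2cccc3ncccc23)CC1)[C@H]1CCc2nc(N)sc2C1` gives 1.6 nM. The step of a 1.5-fold lower number from compound 1 to compound 2 (0.17 log units; within the scatter) stays within the scatter, whereas a 6.2-fold lower number from compound 1 to compound 3 (0.79 log units; beyond the scatter) and a 4.2-fold lower number from compound 2 to compound 3 (0.62 log units; beyond the scatter) go beyond it. Compound 4 `CCCN(CC[C@H]1CC[C@H](NC(=O)c2ccc(-c3noc(C)n3)cc2)CC1)[C@H]1CCc2nc(N)sc2C1` arises from compound 1 through the change (4-(5-methyl-1,2,4-oxadiazol-3-yl)phenyl in place of 2-(3-fluorophenyl)ethenyl on a carbonyl carbon). As in the step from compound 1 to compound 3, the double-bonded chain is replaced by an aromatic group placed directly on the carbonyl carbon, and that step was a 6.2-fold lower number from compound 1 to compound 3 (0.79 log units; beyond the scatter). A modest lowering of the number is therefore expected, a 3.3-fold lower number from compound 1 to compound 4 (0.52 log units; beyond the scatter). Compound 4 is expected to give 3 nM, with a range from 1 nM to 10 nM.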

Compound 4, inhibition constant: 1.3 nM
Compound 4: middle estimate off by 2.3-fold (0.36 log units), on the high side; the measured number falls inside the stated range.
By their numbers in this assay, from the lowest: compounds 4 and 3 (each within the scatter of the next); then compounds 2 and 1 (each within the scatter of the next).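

In this assay, the 4-(5-methyl-1,2,4-oxadiazol-3-yl)phenyl group on the carbonyl carbon gives a 7.6-fold lower number from compound 1 to compound 4 (0.88 log units; beyond the scatter) and also a 5.2-fold lower number from compound 2 to compound 4 (0.71 log units; beyond the scatter) in the same direction, so a second aromatic group placed directly on that carbon also gives a lower number than either ethenyl-linked group. Quinolin-5-yl and this new group are not told apart, with a 1.2-fold lower number from compound 3 to compound 4 (0.09 log units; within the scatter) despite their different rings. Nothing available explains these steps. Going by these compounds, whether a plain phenyl, or a phenyl carrying an amine or a carboxylic acid, would keep the number this low remains open.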